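This account rests on a few compounds, and the source may have more. Where it says the series, first, only, none or still open, it means among the compounds named here.

Compound 1, `O=C(COc1ccc(C(=O)/C=C/c2ccc(Cl)cc2Cl)cc1)N[C@H]1CCOC1=O`, gives 8040 nM in a functional assay on PC-3 cells (Homo sapiens) for antiproliferative activity, read by MTT assay, with a stated time of 72 h; on this read-out higher numbers stand for weaker inhibition and lower numbers for stronger inhibition.
Compound 2, `CC(C)c1ccc(NCC(=O)N[C@H]2CCOC2=O)cc1`, gives > 64000 nM in this assay, which is a limit of the assay and not a number.
Compound 3, `O=C(COc1ccc(C(=O)/C=C/c2cccc([N+](=O)[O-])c2)cc1)N[C@H]1CCOC1=O`, gives 56300 nM in this assay.

For the measured compounds named here, compound 1 and compound 3 share one core, and the single measured step between them is a 7.0-fold higher number from compound 1 to compound 3 (0.85 log units; beyond the scatter). Compound 2 belongs to a different core, and in this assay it stands only at the limit, where (the limit of > 64000 nM in this assay, at which 1 of the 3 values shown sits). No numbered value exists for compound 2, so its position among the three can be given only as the weakest end of what was recorded.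

Compound 4, `O=C(CNc1ccc(F)cc1)N[C@H]1CCOC1=O`, differs from compound 2 in one place: fluoro in place of isopropyl on an aromatic carbon. Going by the values given here, no measured step covers this kind of change; the one measured step, between compound 1 and compound 3, concerns another ring on another core and gives no direct guide here. Since compound 2 is recorded only at the limit, the expected step of a number no higher from compound 2 to compound 4 (the limit leaves the size open) is taken as none beyond the scatter. In this assay compound 4 is therefore estimated at 64000 nM, with a range from 20000 nM to 200000 nM, and a limit is expected to be the most likely outcome.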

Compound 4, half-maximal inhibitory concentration: > 64000 nM
Compound 4 gave a limit, no number; the forecaster's own chance of this, stated with the estimate: 60%; the middle value sits exactly at the limit.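

In this assay compound 2 and compound 4 both stand at a limit of the assay and not at a number, so no step can be read between them: the limit of > 64000 nM in this assay, at which 2 of the 4 values shown sit.
What the compounds shown leave open is whether fluoro in place of isopropyl on an aromatic carbon changes the inhibition at all, and how far beyond the limit either compound lies.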